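The source may report more compounds than this note shows. Statements on the series, on what has been measured and on what is new or still open speak of the compounds shown alone.

Compound 2 `O[C@@H]1CCCc2nc(C#Cc3ccccc3)ccc21` and compound 1 `O[C@H]1CCCc2nc(C#Cc3ccccc3)ccc21` share one core; as the fact that compounds 1 and 2 differ only in the configuration as drawn states, they differ only in how the stereocentre at a saturated ring carbon is drawn. In an assay on isolated protein for displacement of a labelled ligand from metabotropic glutamate receptor 5 (Rattus norvegicus) (on this read-out lower numbers stand for stronger inhibition and higher numbers for weaker inhibition), compound 1 gives 9280 nM and compound 2 gives 4710 nM, and the step of a 2.0-fold lower number from compound 1 to compound 2 (0.29 log units; within the scatter) leaves the two within the scatter of each other. Compound 3 `C(#Cc1ccc2c(n1)CCCC2)c1ccccc1` carries hydrogen in place of hydroxy on a saturated ring carbon. For the measured compounds named here, no measured step removes this group, so the single step available does not bear directly on it; it only shows that flipping the hydroxy changes little. For compound 3 the step of a 1.6-fold lower number from compound 2 to compound 3 (0.20 log units; within the scatter) is expected, giving an estimated 3000 nM with a range from 800 nM to 12000 nM.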

Compound 3, inhibition constant: 1500 nM
Compound 3: the middle estimate sits 2.0-fold (0.30 log units) above what was measured; the range from low to high includes it.
By their numbers in this assay, from the lowest: compound 3; then compounds 2 and 1 (each within the scatter of the next).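

For the compounds shown here, replacing the hydroxy with hydrogen is the first change at this saturated ring carbon to go beyond the scatter (a 3.1-fold lower number from compound 2 to compound 3 (0.50 log units; beyond the scatter)) and (a 6.2-fold lower number from compound 1 to compound 3 (0.79 log units; beyond the scatter)), both modest steps towards stronger inhibition in this assay. (The two steps start from structures of the same atoms and bonds: the fact that compounds 1 and 2 differ only in the configuration as drawn). At this position, then, removing the hydroxy counts for more than how it is drawn.

As far as these compounds go, whether a methyl, a fluorine or an amine on this carbon would behave like hydrogen or like hydroxy stays open. Why the hydroxy costs inhibition also stays open.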